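A few compounds are considered here, and "the series" means these few. Any claim that something is new, unique, unknown or untested is made for them only; others in the source may bear on it.

Among the measured compounds shown here, compound 2 `Cc1cccc(COc2c(-c3ccccc3)oc3cc(O)cc(O)c3c2=O)c1` is the only compound with a plain number in an ADME assay on Huh-5-2 cells (Homo sapiens) for cytotoxicity, read by WST assay, with a stated time of 3 days (a higher number here means that more compound is tolerated, a lower number that less compound is tolerated), where compound 2 gives 29000 nM. Compound 1 `N#Cc1ccccc1COc1c(-c2ccccc2)oc2cc(O)cc(O)c2c1=O` reaches only a limit of the assay in this assay, giving > 100000 nM. For the measured compounds named here, the one measured step, an at least 3.4-fold lower number from compound 1 to compound 2 (0.53 log units; beyond the scatter), therefore starts from that limit (the limit of > 100000 nM in this assay, at which 1 of the 2 values shown sits). Compound 3 `O=c1c(OCc2ccc(Br)cc2)c(-c2ccccc2)oc2cc(O)cc(O)c12` differs from compound 2 by 4-bromophenyl in place of 3-methylphenyl on a saturated chain carbon bound to an oxygen on an aromatic ring. Going by the values given here, no measured step exchanges one ring substituent for another away from the limit, and no change beyond the scatter is expected in this assay. Compound 3 is estimated at 30000 nM, between 10000 nM and 100000 nM. This means an expected step of a 1.0-fold higher number from compound 2 to compound 3 (0.01 log units; within the scatter).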

Compound 3, half-maximal cytotoxic concentration: 2000 nM
The estimate for compound 3 lay 15-fold (1.18 log units) above the measured number, and the stated range ends above it.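

In this assay, a swap on the saturated chain carbon bound to an oxygen on an aromatic ring moves the number well beyond the scatter between two plain values: a 15-fold lower number from compound 2 to compound 3 (1.16 log units; beyond the scatter). The exchange of 2-cyanophenyl for 4-bromophenyl gives an at least 50-fold lower number from compound 1 to compound 3 (1.69 log units; beyond the scatter). Compound 1 stands at a limit rather than a number, so that step has no fixed size: the limit of > 100000 nM in this assay, at which 1 of the 3 values shown sits.

Going by these compounds, whether the drop follows the bromine or its place on the ring stays open, since 3-methylphenyl and 4-bromophenyl differ in both. A 4-methylphenyl or 3-bromophenyl group would separate the two, and an amine on the ring remains an open case.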